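Adding a phenyl to the benzyl ether of compound 2

The source may hold more compounds than are shown below. What is called first, only, known or untested is meant among the compounds shown, and "the series" means these compounds.

- compound 1 `COc1ccc(CCCN2CCC(COCc3ccccc3)CC2)cc1` value 2100 nM
- compound 2 `COc1ccc(CCCN2CCC(COCc3ccc(Cl)cc3)CC2)cc1` value 500 nM

In a functional assay on cells (T-cell line, Homo sapiens) for inhibition (on this read-out lower numbers stand for stronger inhibition and higher numbers for weaker inhibition), compound 2 at 500 nM has the lower of the two numbers. Compound 3 `COc1ccc(CCCN2CCC(COC(c3ccccc3)c3ccc(Cl)cc3)CC2)cc1` carries phenyl in place of hydrogen on a saturated chain carbon bound to an aromatic carbon and an oxygen on a saturated carbon. Among the measured compounds shown here, the one measured step of a 4.2-fold lower number from compound 1 to compound 2 (0.62 log units; beyond the scatter) was modest and beyond the scatter, but it concerns chloro in place of hydrogen on an aromatic carbon, so it is only a loose guide. The estimated step of a 2.5-fold lower number from compound 2 to compound 3 (0.40 log units; beyond the scatter) is expected in this assay as a modest move to a lower number. For compound 3 the estimate is 200 nM with an expected range of 50 nM to 800 nM on this read-out.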

Compound 3, half-maximal inhibitory concentration: 200 nM
Compound 3: the middle estimate sits on the measured number at the digits printed, and the stated range covers the measured number.
By their numbers in this assay, from the lowest: compound 3; then compound 2; then compound 1.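

In this assay the saturated chain carbon bound to an aromatic carbon and an oxygen tolerates phenyl in place of hydrogen and shows a 2.5-fold lower number from compound 2 to compound 3 (0.40 log units; beyond the scatter) as a modest gain, so a change at this carbon, and not only on the aromatic ring, moves the number. Read as 4-chlorophenyl in place of hydrogen at that carbon, the change gives an 11-fold lower number from compound 1 to compound 3 (1.02 log units; beyond the scatter) as a large step. Nothing measured here explains either step.

Still open, from the compounds shown here alone, is whether a methyl or a pyridyl at this carbon would serve as well as phenyl. Going by these compounds, a fluoro or methoxy on the added phenyl also remains untested in these notes.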